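The source may report more compounds than this note shows. Statements on the series, on what has been measured and on what is new or still open speak of the compounds shown alone.

Measured compounds:
Compound 1, `COC(=O)[C@H](O)[C@H]1C(=O)N2C(C(=O)O)=C(C(C)(C)C)O[C@H]12`, which in an ADME assay, in phosphate buffer, at 28 degrees C, at pH 7.0 (on this read-out lower numbers stand for a shorter-lived compound and higher numbers for a longer-lived compound), gives 6.7 h.
Compound 2, `C[C@@H](F)[C@H]1C(=O)N2C(C(=O)O)=C(C(C)(C)C)O[C@H]12`, which in this assay gives 3.5 h.

Compound 2 stands alongside compound 1 on the numbers shown: the step of a 1.9-fold lower number from compound 1 to compound 2 (0.28 log units; within the scatter) is within the scatter, so the two compounds are not separated on this read-out. Compound 3, `CC(C)(C)C1=C(C(=O)O)N2C(=O)[C@H](CNS(C)(=O)=O)[C@H]2O1`, differs from compound 2 by (methanesulfonamido)methyl in place of 1-fluoroethyl on a saturated ring carbon. Within the data shown here, the only measured step that bears on this position is a 1.9-fold lower number from compound 1 to compound 2 (0.28 log units; within the scatter), an exchange of one group on that same saturated ring carbon for another, and it stayed within the scatter. With that single comparison there is no ground to expect a shift in this assay beyond the scatter in either direction, and with two compounds no pattern can be claimed. Compound 3 is therefore expected at 5 h, within a range from 2.5 h to 10 h. This estimate corresponds to an expected step of a 1.4-fold higher number from compound 2 to compound 3 (0.15 log units; within the scatter).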

Compound 3, half-life: 2.2 h
Beside the measured number, compound 3's estimate is 2.3-fold (0.36 log units) above it, outside the stated range (below it).
By their numbers in this assay, from the lowest: compounds 3, 2 and 1 (each within the scatter of the next, the first and the last beyond it).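

In this assay, the exchange of 1-fluoroethyl for (methanesulfonamido)methyl on the saturated ring carbon gives a 1.6-fold lower number from compound 2 to compound 3 (0.20 log units; within the scatter), so these two groups are not separated on this read-out. Among these compounds, the exchange of hydroxy(methoxycarbonyl)methyl for (methanesulfonamido)methyl on that same carbon gives a 3.0-fold lower number from compound 1 to compound 3 (0.48 log units; beyond the scatter), the first step at this position to pass the scatter, which shows that the group held there can modestly shift the half-life. No measurement shown here accounts for this difference.

The compounds shown leave open which part of the hydroxy(methoxycarbonyl)methyl group goes with the step from compound 1 to compound 3. They also leave open how an amine, a carboxylic acid or a longer alkyl chain on this ring carbon would read in this assay.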